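Silyl Removal in a Diaryl Cyclopentenone Series on DU-145 Cells

The source may hold more compounds than are shown below. What is called first, only, known or untested is meant among the compounds shown, and "the series" means these compounds.

The study examines a small set of diaryl cyclopentenones in an ADME assay on DU-145 cells (Homo sapiens) for cytotoxicity, read by MTT assay, with a stated time of 72 h; a higher number here means a weaker inhibitor, a lower number a stronger inhibitor. For the measured compounds named here, compound 1, with the structure `COc1ccc(OC)c(C2=C(c3cc(OC)c(OC)c(OC)c3)C(=O)CC2O[SiH2]C(C)(C)C)c1`, gives 100 ug/mL in this assay, the only plain number in the set. Compound 2, with the structure `COc1ccc(C2=C(c3cc(OC)c(OC)c(OC)c3)CC(O)C2=O)cc1[N+](=O)[O-]`, is reported at the limit > 100 ug/mL in this assay. Compound 3, with the structure `COc1ccc(C2=C(c3cc(OC)c(OC)c(OC)c3)CC(O[SiH2]C(C)(C)C)C2=O)cc1[N+](=O)[O-]`, is likewise reported at the limit > 100 ug/mL in this assay. Between these two the change a hydrogen atom in place of a group of 5 heavy atoms (4 carbon, 1 silicon; no ring), on an oxygen on a saturated carbon produced the step that the two limits leave unreadable from compound 3 to compound 2, a step that both limits leave unreadable, as the limit of > 100 ug/mL in this assay, at which 2 of the 3 values shown sit, shows. The difference between the core of compound 1 and the core of compound 3 is not broken down here.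

Compound 4, with the structure `COc1ccc(OC)c(C2=C(c3cc(OC)c(OC)c(OC)c3)C(=O)CC2O)c1`, is not yet measured. It stands to compound 1 as compound 2 stands to compound 3: the same change, (a hydrogen atom in place of a group of 5 heavy atoms (4 carbon, 1 silicon; no ring), on an oxygen on a saturated carbon). The estimated step of a 1.1-fold higher number from compound 1 to compound 4 (0.04 log units; within the scatter) rests only on compound 1 giving 100 ug/mL and on the unreadable step that the two limits leave unreadable from compound 3 to compound 2. Compound 4 is therefore expected to give about 110 ug/mL in this assay, plausibly between 50 ug/mL and 300 ug/mL.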

Compound 4, half-maximal inhibitory concentration: > 100 ug/mL
Compound 4 was reported as a limit (the forecaster's own chance of this, stated with the estimate: 55%); the middle value does not contradict the limit.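

Replacing the group of 5 heavy atoms (4 carbon, 1 silicon) with hydrogen, on an oxygen on a saturated carbon, gives a number no lower from compound 1 to compound 4 (the limit leaves the size open) in this assay, so on the core of compound 1 the change brings no lower number. On the core of compound 3 the same change yields a step between two limits, and so the change shows no lower number on either core only as far as these limits allow. Neither step can be read for size, which leaves it unshown whether the change acts to the same extent on the two cores: the limit of > 100 ug/mL in this assay, at which 3 of the 4 values shown sit.

For the compounds shown here, compound 1 stays the only compound with a plain number, 100 ug/mL, so the series offers no measured value for comparison. The compounds shown leave open what an amine or a carboxylic acid would give on the saturated ring carbon in place of that oxygen, or what a longer chain would give on the oxygen itself.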